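Ring exchange at the sulfur-linked carbon toward compound 4

The source may report more compounds than this note shows. Statements on the series, on what has been measured and on what is new or still open speak of the compounds shown alone.

Compound 3 `O=C1CCCC(CSc2nc(-c3ccccc3)c(-c3ccccc3)[nH]2)O1` gives 740 nM in an assay on microsomes from liver for inhibition of sterol O-acyltransferase 1 (Rattus norvegicus) (on this read-out lower numbers stand for stronger inhibition and higher numbers for weaker inhibition), the highest of the three measured numbers. Compound 1 `C[C@@]1(O)CC(=O)OC(CSc2nc(-c3cccc(Cl)c3)c(-c3cccc(Cl)c3)[nH]2)C1` gives 110 nM in this assay, and compound 2 `CC1=CC(=O)OC(CSc2nc(-c3cccc(Cl)c3)c(-c3cccc(Cl)c3)[nH]2)C1` gives 440 nM; the gap between compound 2 and compound 3 lies within the scatter, while the gap between compound 1 and compound 3 lies beyond it.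

Compound 4 `c1ccc(-c2nc(SCC3OCCCO3)[nH]c2-c2ccccc2)cc1` differs from compound 3 by a group of 6 heavy atoms (4 carbon, 2 oxygen; one six-membered non-aromatic ring with 2 hetero atoms) in place of a group of 7 heavy atoms (5 carbon, 2 oxygen; one six-membered non-aromatic ring with 1 hetero atom), on a saturated chain carbon bound to a sulfur. For the measured compounds named here, the only measured step at the same place is a 4.0-fold higher number from compound 1 to compound 2 (0.60 log units; beyond the scatter), and there the ring kept a single hetero atom and its double bond outside aromatic rings in both partners; compound 1 and compound 2 also carry chlorine on their aryl groups, which compound 3 and compound 4 do not. That precedent shows that altering the ring at this position moves the number modestly. Going by the values given here, no measured compound carries a ring with two hetero atoms or lacks the double bond outside aromatic rings, so the direction rests on a single indirect precedent pointing toward a weaker result. Compound 4 is expected to give about 1500 nM in this assay, with a range from 500 nM to 5000 nM. This expectation corresponds to a 2.0-fold higher number from compound 3 to compound 4 (0.31 log units; beyond the scatter).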

Compound 4, half-maximal inhibitory concentration: 180 nM
Estimate against measurement, compound 4: 8.3-fold (0.92 log units) above; measured number below the stated range.
By their numbers in this assay, from the lowest: compounds 1 and 4 (each within the scatter of the next); then compounds 2 and 3 (each within the scatter of the next).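

In this assay, the ring exchange gives a 4.1-fold lower number from compound 3 to compound 4 (0.61 log units; beyond the scatter), so on a saturated chain carbon bound to a sulfur, a six-membered non-aromatic ring with 2 hetero atoms and no double bond outside aromatic rings is compatible with a lower number than the ring it replaces. The only earlier step at this place, a 4.0-fold higher number from compound 1 to compound 2 (0.60 log units; beyond the scatter), went the other way, so the listed ring changes here move the number in either direction, both by a modest amount, although that earlier pair carries chlorine on its aryl groups and the new pair does not. No supporting data bear on what underlies this lower number.

Going by these compounds, it remains open whether the ring with 2 hetero atoms would give a similar step on the chlorine-bearing aryl groups of compound 2, where the shared core differs from that of compound 4. Also open, on these data alone, is how an amine or a carboxylic acid on the saturated chain carbon bound to a sulfur would compare with either ring in this assay.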